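Cyclohexylmethyl for cyclopropyl on the benzimidazole nitrogen

This account rests on a few compounds, and the source may have more. Where it says the series, first, only, none or still open, it means among the compounds named here.

Measured so far:
compound 1 `CCC(CC)n1c(-c2ccc(OCc3c(-c4c(Cl)cccc4Cl)noc3C(C)C)cc2Cl)nc2ccc(C(=O)O)cc21`: 21.6 nM
compound 2 `CC(C)c1onc(-c2c(Cl)cccc2Cl)c1COc1ccc(-c2nc3ccc(C(=O)O)cc3n2C2CC2)cc1`: 117 nM
compound 3 `CC(C)c1onc(-c2c(Cl)cccc2Cl)c1COc1ccc(-c2nc3ccc(C(=O)O)cc3n2C2CCCC2)cc1`: "not determined" (no result reported)

In an assay on isolated protein for agonist activity at Bile acid receptor (Homo sapiens), read by TR-FRET (on this read-out lower numbers stand for an effect already at smaller amounts and higher numbers for an effect only at larger amounts of compound), compound 2 gives 117 nM, the higher of the two numbers available. Its nearest neighbour is compound 1, whose value of 21.6 nM lies well beyond the scatter from it; compound 1 differs from compound 2 in more than one place, so that gap cannot be pinned on a single change. Compound 3, another variation at the same ring nitrogen, has no number at all, only "not determined" (no result reported).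

The step to compound 4 `CC(C)c1onc(-c2c(Cl)cccc2Cl)c1COc1ccc(-c2nc3ccc(C(=O)O)cc3n2CC2CCCCC2)cc1` is one clean change: cyclohexylmethyl in place of cyclopropyl on an aromatic nitrogen

Among the measured compounds shown here, with no step between measured compounds to lean on, the expectation rests on the only other number: compound 1 carries a different group at that nitrogen and gives 21.6 nM, a lower number than that of compound 2. The step from compound 2 to compound 4 is therefore expected to be a 2.3-fold lower number from compound 2 to compound 4 (0.37 log units; beyond the scatter), a moderate move toward smaller amounts in this assay. Compound 4 is estimated at 50 nM, with a plausible range from 15 nM to 180 nM.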

Compound 4, half-maximal effective concentration: 19.9 nM
Compound 4: the middle estimate sits 2.5-fold (0.40 log units) above what was measured; measured number inside the range.
By their numbers in this assay, from the lowest: compounds 4 and 1 (each within the scatter of the next); then compound 2.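

In this assay, among the compounds shown here, replacing cyclopropyl with cyclohexylmethyl on the aromatic nitrogen gives a 5.9-fold lower number from compound 2 to compound 4 (0.77 log units; beyond the scatter), the first step here that can be read as a single change at this position. It shows that this nitrogen can carry a group of 7 heavy atoms instead of 3, all of them carbon, and that here the larger group goes with a lower number, not a higher one. No measurement here explains this shift.

One step cannot separate the contribution of the six-membered ring from that of the carbon linking it to the nitrogen, so a directly attached cyclohexyl, a benzyl group or an open hexyl chain would each be informative at this position. Going by these compounds, how an amine or a hydroxyl group on the cyclohexyl ring would read also remains open.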